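Ethoxy to chloro on the (4-ethoxyphenyl)carbonyl arm

The source may hold more compounds than are shown below. What is called first, only, known or untested is meant among the compounds shown, and "the series" means these compounds.

Of the compounds shown here, three have numbers so far in a functional assay on HepG2 cells (Homo sapiens) for antiproliferative activity, read by MTT assay, with a stated time of 48 h; on this read-out higher numbers stand for weaker inhibition and lower numbers for stronger inhibition. Compound 1 `CCOc1ccc(C(=O)/C=C/c2c(/C=C/c3ccc(OC)cc3)cc(OC)cc2OC)cc1` gives 8 ug/mL in this assay, the lowest of the three numbers, but the gaps to the other two lie within the scatter. Compound 2 `COc1ccc(/C=C/c2cc(OC)cc(OC)c2/C=C/C(=O)c2ccc(Cl)c(Cl)c2)cc1` gives 10.8 ug/mL and compound 3 `COc1ccc(/C=C/c2cc(OC)cc(OC)c2/C=C/C(=O)c2ccc(-c3ccccc3)cc2)cc1` gives 10.5 ug/mL. The step of a 1.4-fold higher number from compound 1 to compound 2 (0.13 log units; within the scatter) and the step of a 1.3-fold higher number from compound 1 to compound 3 (0.12 log units; within the scatter) both stay within the scatter, as does a 1.0-fold lower number from compound 2 to compound 3 (0.01 log units; within the scatter); across these three the aryl group on the carbonyl has so far made no difference that can be told from repeat measurements.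

Compound 4 `COc1ccc(/C=C/c2cc(OC)cc(OC)c2/C=C/C(=O)c2ccc(Cl)cc2)cc1` is not yet measured. Relative to compound 1 it shows (chloro in place of ethoxy on an aromatic carbon). The nearest measured step is a 1.4-fold higher number from compound 1 to compound 2 (0.13 log units; within the scatter), where the ethoxy-bearing ring was exchanged for a chlorine-bearing one; it too stayed within the scatter. On that basis no step beyond the scatter is expected for compound 4 in this assay, and the estimated step of a 1.1-fold higher number from compound 1 to compound 4 (0.05 log units; within the scatter) is taken as flat, because a 1.4-fold higher number from compound 1 to compound 2 (0.13 log units; within the scatter) was flat. Compound 4 is therefore expected to give 9 ug/mL in this assay, within a range from 4.5 ug/mL to 18 ug/mL.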

Compound 4, half-maximal inhibitory concentration: 13.6 ug/mL
Compound 4: the middle estimate sits 1.5-fold (0.18 log units) below what was measured, within the range that was stated.
By their numbers in this assay, from the lowest: compounds 1, 3, 2 and 4 (each within the scatter of the next).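

In this assay the exchange of ethoxy for chloro on an aromatic carbon, para to a large group, can now be read directly on the (4-ethoxyphenyl)carbonyl arm: a 1.7-fold higher number from compound 1 to compound 4 (0.23 log units; within the scatter) leaves the change from three heavy atoms and one hydrogen-bond acceptor to a single chlorine atom without a step that can be told from repeat measurements. The same carbon also shows no such step for chloro in place of phenyl, with a 1.3-fold higher number from compound 3 to compound 4 (0.11 log units; within the scatter) as the reading, and the 3,4-dichlorophenyl and 4-chlorophenyl arms, which differ by one chloro, add a 1.3-fold higher number from compound 2 to compound 4 (0.10 log units; within the scatter) as a further flat reading, so that all four aryl arms shown remain indistinguishable on this read-out and no order among them can be drawn. No measurement is available that could account for this flat picture.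

The compounds shown leave open whether an amine, a carboxylic acid or a longer alkoxy chain such as butoxy on this carbon would produce a step beyond the scatter. They also leave open whether an arm with no substituent at all, or with a hydroxyl group, would stay equally flat on the shared core.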